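Methylsulfonyl for hydroxy on the pendant phenyl of compound 1

This account rests on a few compounds, and the source may have more. Where it says the series, first, only, none or still open, it means among the compounds named here.

Compound 1 `CCCS(=O)(=O)Nc1ccc(F)c(C(=O)c2n[nH]c3ncc(-c4ccc(O)cc4)cc23)c1F` is the reference of the series. In an assay for binding affinity to dual specificity mitogen-activated protein kinase kinase 4 (Homo sapiens), read by KINOMEscan, tested at 100 nM (a higher number here means a weaker effect of the compound at the concentration tested, a lower number a stronger effect), compound 1 gives 0.75%, the lowest of the three numbers recorded. Compound 2 `CCCS(=O)(=O)Nc1ccc(F)c(C(=O)c2n[nH]c3ncc(-c4ccc(N(C)C)cc4)cc23)c1F` gives 2.5%, and the step of a number 1.8 percentage points higher from compound 1 to compound 2 (within the scatter) stays inside the usual scatter. Compound 3 `CCCS(=O)(=O)Nc1ccc(F)c(C(=O)c2n[nH]c3ncc(-c4cccc(C(F)(F)F)c4)cc23)c1F` gives 57%; the steps of a number 56.3 percentage points higher from compound 1 to compound 3 (beyond the scatter) and a number 54.5 percentage points higher from compound 2 to compound 3 (beyond the scatter) are both large and beyond the scatter.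

Compound 4 `CCCS(=O)(=O)Nc1ccc(F)c(C(=O)c2n[nH]c3ncc(-c4ccc(S(C)(=O)=O)cc4)cc23)c1F` has not yet been measured. It differs from compound 1 as follows: methylsulfonyl in place of hydroxy on an aromatic carbon. The change sits on the aromatic carbon para to a large group, the same place where compound 1 and compound 2 differ.

The step that bears most directly is a number 1.8 percentage points higher from compound 1 to compound 2 (within the scatter), a swap at that same place that left the number within scatter. The large steps to compound 3 involve a different ring substitution pattern and therefore speak less to compound 4. A step of a number 5.3 percentage points higher from compound 1 to compound 4 (within the scatter) is expected, small and possibly within the scatter, with the risk of weaker binding given the pattern seen elsewhere. Compound 4 is estimated at 6%, in the range 1% to 35%.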

Compound 4, a percentage reported as activity, at one concentration (the size of the read-out at that concentration, not a potency): 1.5%
For compound 4 the middle estimate is 4.5 percentage points above the measured one; the range from low to high includes it.
By their numbers in this assay, from the lowest: compounds 1, 4 and 2 (each within the scatter of the next); then compound 3.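

In this assay, methylsulfonyl in place of hydroxy gives a number 0.8 percentage points higher from compound 1 to compound 4 (within the scatter), and methylsulfonyl in place of dimethylamino gives a number 1 percentage points lower from compound 2 to compound 4 (within the scatter), so three different groups on the aromatic carbon para to a large group now read alike. The entering methylsulfonyl counts 0 hydrogen-bond donors and 4 heavy atoms against 1 donor and 1 heavy atom for hydroxy, so a hydrogen-bond donor on this group is not needed for a low number in this small set. Among these compounds, the change to 4-(methylsulfonyl)phenyl in place of 3-(trifluoromethyl)phenyl gives a number 55.5 percentage points lower from compound 3 to compound 4 (beyond the scatter), which leaves compound 3 as the only high reading among the four, and nothing at hand explains why.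

Compound 3 differs from the others in both the group and its place on the ring, so the compounds shown do not separate these two changes, and trifluoromethyl on the carbon that carries hydroxy in compound 1 would do so. From the compounds shown here alone, a carboxylic acid or a primary amine at that carbon remains open, as does any ranking of compound 1, compound 2 and compound 4, whose readings at one concentration lie within the scatter of each other.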